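Adding an Amino Group to a Pyrrolopyridine Acetamide

The compounds below may be only part of what the source reports. "The series", "measured", "known", "first", "only" and "open" are said of these compounds alone.

Compound 1 `Nc1cc(-c2cnc3[nH]cc(-c4ccncc4)c3c2)ccc1Cl` gives 53.7 nM in an assay on isolated protein for inhibition of high affinity nerve growth factor receptor (Homo sapiens), read by 33P incorporation; a lower number here means a stronger inhibitor, a higher number a weaker inhibitor.
Compound 2 `CC(=O)Nc1cccc(-c2cnc3[nH]cc(-c4ccncc4)c3c2)c1` gives 34.3 nM in this assay.

Of the two numbers measured, compound 2 has the lowest, but compound 1 sits within the usual scatter of it, so the two cannot be told apart on these data. Compound 3 `CC(=O)Nc1cc(N)cc(-c2cnc3[nH]cc(-c4ccncc4)c3c2)c1` is not yet measured. It differs from compound 2 by amino in place of hydrogen on an aromatic carbon. Both compounds keep the shared core, and compound 1 already carries an amino group on its outer ring while giving a number close to that of compound 2. Going by the values given here, no pair of measured compounds that differs in one place is available, so there is nothing to show how much a single added group shifts the read-out here. The expected step from compound 2 to compound 3 is a 1.2-fold higher number from compound 2 to compound 3 (0.07 log units; within the scatter), within the scatter rather than a clear change in either direction. Compound 3 is therefore estimated at 40 nM, with a range from 15 nM to 110 nM.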

Compound 3, half-maximal inhibitory concentration: 5.41 nM
For compound 3 the middle estimate is 7.4-fold (0.87 log units) above the measured one; measured number below the stated range.
By their numbers in this assay, from the lowest: compound 3; then compounds 2 and 1 (each within the scatter of the next).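

In this assay, putting an amino group in place of hydrogen on the outer carbon ring, meta to an acetamido group, gives a 6.3-fold lower number from compound 2 to compound 3 (0.80 log units; beyond the scatter), and this step lies beyond the usual scatter. Going by these compounds alone, this is the first single change with a readable effect, and it shows that this ring position is not indifferent: one added amino group is enough to make a stronger inhibitor. Nothing available explains how the amino group produces this gain.

Going by these compounds, it remains open whether the gain belongs to the amino group itself, or whether a hydroxyl, a methyl or a methylamino group at the same position would give a similar number. On these data alone, it is also open whether the amino group would have the same effect with a different group in place of the acetamido group.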